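Hydroxy to propylamino on an amide-type nitrogen

A few compounds are considered here, and "the series" means these few. Any claim that something is new, unique, unknown or untested is made for them only; others in the source may bear on it.

Measured in an ADME assay on Huh-7 cells (Homo sapiens) for cytotoxicity, read by MTT assay, with a stated time of 3 days; a lower number here means that less compound is tolerated, a higher number that more compound is tolerated:
Compound 1 `CCCNNC(=O)CCc1ccccc1`: 96000 nM
Compound 2 `Cc1nc2ccccc2n1Cc1ccc(C(=O)NO)cc1`: 7900 nM

Compound 2 gives 7900 nM, the lower of the two numbers. Compound 1 gives 96000 nM, and the gap between the two lies beyond the usual scatter. The two compounds differ in more than one place, so no single structural change can be read from this gap.

Compound 3 `CCCNNC(=O)c1ccc(Cn2c(C)nc3ccccc32)cc1` is still unmeasured. It carries propylamino in place of the hydroxy of compound 2 on an amide-type nitrogen propylamino in place of hydroxy on an amide-type nitrogen and keeps the rest of that structure.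

For the measured compounds named here, the only guide is compound 1, which also bears propylamino on an amide-type nitrogen and gives 96000 nM. That single value cannot separate the group from the rest of its structure, so only a small upward move is expected in this assay, one that may not clear the scatter. The expected shift is a 1.9-fold higher number from compound 2 to compound 3 (0.28 log units; within the scatter). For compound 3 the estimated value is 15000 nM, with an expected range of 4000 nM to 50000 nM.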

Compound 3, half-maximal cytotoxic concentration: 9900 nM
Compound 3: middle estimate off by 1.5-fold (0.18 log units), on the high side; measured number inside the range.
By their numbers in this assay, from the lowest: compounds 2 and 3 (each within the scatter of the next); then compound 1.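

In this assay, for the compounds shown here, the single change of propylamino in place of hydroxy on an amide-type nitrogen gives a 1.3-fold higher number from compound 2 to compound 3 (0.10 log units; within the scatter), so on this core the swap of a hydroxy of one heavy atom for a propylamino of four heavy atoms, with the donor and acceptor counts unchanged, is not separated from the hydroxy parent by this read-out. Going by these compounds alone, this is the first step that isolates one change, and it shows that propylamino at this place does not by itself shift the tolerated concentration beyond the scatter on the core shared by compound 2 and compound 3, whereas the earlier pair could not separate the group from the rest of the structure. No measured property is available to give a reason for this result.

What sets compound 1 apart remains unassigned, and a hydroxy on the amide-type nitrogen of the core of compound 1 would be needed to test whether the same change reads alike there. Also open, going by these compounds, is whether a longer chain such as hexylamino, a primary amine or a carboxylic acid at this place on the shared core would stay equally close to compound 2.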